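A few compounds are considered here, and "the series" means these few. Any claim that something is new, unique, unknown or untested is made for them only; others in the source may bear on it.

Measured so far in a functional assay on Jurkat cells (Homo sapiens) for cytotoxicity, with a stated time of 72 h; on this read-out higher numbers stand for an effect only at larger amounts of compound and lower numbers for an effect already at smaller amounts:
- compound 1 `C=C[C@@](C)(/C=C/c1ccc(O)c(/C=C/C(=O)OCC)c1)CCC=C(C)C`: > 49000 nM (a limit)
- compound 2 `COc1ccc(/C=C/[C@@](C)(/C=C/c2ccc(O)c(C=O)c2)CCC=C(C)C)cc1`: > 49000 nM (a limit)
- compound 3 `COc1ccc(/C=C/[C@@](C)(/C=C/c2ccc(O)c(/C=C/C#N)c2)CCC=C(C)C)cc1`: > 49000 nM (a limit)

Compound 3 has no number, only a limit, and the series as a whole shows (the limit of > 49000 nM in this assay, at which 3 of the 3 values shown sit). Compound 4 `CCOC(=O)/C=C/c1cc(/C=C/[C@](C)(/C=C/c2ccc(OC)cc2)CCC=C(C)C)ccc1O` differs from compound 3 as follows: ethoxycarbonyl in place of cyano on a double-bonded chain carbon bound to a double-bonded chain carbon. In words, this is ethoxycarbonyl in place of cyano on a double-bonded chain carbon bound to a double-bonded chain carbon.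

For the measured compounds named here, the only measured step involving the 2-cyanoethenyl group, a step that the two limits leave unreadable from compound 2 to compound 3, gives no size to build on. Compound 1 also carries 2-(ethoxycarbonyl)ethenyl and gives > 49000 nM, again a limit. No readable shift in either direction is therefore expected in this assay, and the expected step is a step that the limit leaves unreadable from compound 3 to compound 4. The estimate for compound 4 is 50000 nM, with an expected range of 20000 nM to 100000 nM, most likely reported as a limit again.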

Compound 4, half-maximal effective concentration: > 49000 nM
Compound 4 was reported as a limit; the forecaster's own chance of this, stated with the estimate: 85%; the middle value lies beyond the limit too.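

For the compounds shown here, no step from compound 1, compound 2 or compound 3 to compound 4 can be read in this assay, and all four compounds give only a limit: the limit of > 49000 nM in this assay, at which 4 of the 4 values shown sit. From the compounds shown here alone, whether any of these group changes alters the read-out stays open.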